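Swapping aminophenyl for hydroxyphenyl on a methylated core

The compounds below may be only part of what the source reports. "The series", "measured", "known", "first", "only" and "open" are said of these compounds alone.

Compound 1 `COc1ccc(-c2cc3ccccc3c(-c3cccc(N)c3)n2)cc1` carries a 3-aminophenyl on its core. In a functional assay on DU-145 cells (Homo sapiens) for cytotoxicity, read by CCK-8 assay and cell counting, with a stated time of 72 h (a lower number here means a stronger inhibitor, a higher number a weaker inhibitor), compound 1 gives 8610 nM. Compound 2 `COc1ccc(-c2cc3ccccc3c(-c3ccc(O)cc3)n2)cc1` differs from it in one place (4-hydroxyphenyl in place of 3-aminophenyl on an aromatic carbon). In this assay compound 2 reaches only a limit of the assay, > 50000 nM. The step from an at least 5.8-fold higher number from compound 1 to compound 2 (0.76 log units; beyond the scatter) is therefore at least modest, and it rests on the fact that one of the three values given sits at the limit of > 50000 nM in this assay, at which 1 of the 3 values shown sits.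

Compound 3 `COc1ccc(-c2cc3cc(C)ccc3c(-c3cccc(N)c3)n2)cc1OC` is built on a different core; how its core differs from that of compound 1 is not broken down here. In this assay compound 3 gives 4190 nM, the lowest of the two numbers given; compound 1 sits at a higher number, and that gap lies beyond the usual scatter.

Compound 4 `COc1ccc(-c2cc3cc(C)ccc3c(-c3ccc(O)cc3)n2)cc1OC`, not yet measured, differs from compound 3 in one place (4-hydroxyphenyl in place of 3-aminophenyl on an aromatic carbon). This is the same kind of change as that from compound 1 to compound 2; the surroundings are described slightly differently, as "meta to a large group" here rather than "meta to a 4-methoxyphenyl group (8 heavy atoms)" there. For compound 4 the expected step from a 7.2-fold higher number from compound 3 to compound 4 (0.85 log units; beyond the scatter) is of a similar size to the measured one, because the change from compound 1 to compound 2 gave an at least 5.8-fold higher number from compound 1 to compound 2 (0.76 log units; beyond the scatter). Compound 4 is estimated at 30000 nM, with a range from 10000 nM to 60000 nM, and a real chance that the assay again reports only a limit.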

Compound 4, half-maximal inhibitory concentration: 5980 nM
Compound 4: the middle estimate sits 5.0-fold (0.70 log units) above what was measured, and the stated range ends above it.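

On the core of compound 3, this assay shows that putting 4-hydroxyphenyl in place of 3-aminophenyl gives a 1.4-fold higher number from compound 3 to compound 4 (0.15 log units; within the scatter), a step too small to be told apart from the ordinary variation between repeated measurements. So the change does not carry over from one core to the other at the same size, and the two steps differ: the same change on two cores in this assay, an at least 5.8-fold higher number (0.76 log units; beyond the scatter) from compound 1 to compound 2 and a 1.4-fold higher number (0.15 log units; within the scatter) from compound 3 to compound 4, at least 4.0-fold (0.60 log units) apart, beyond the scatter of two such steps. On these data alone, this shows that the effect of the swap depends on the core in these two pairs, but compound 2 stands only at a limit, so the full size of the first step is unknown, and two pairs cannot show which part of the cores is responsible or predict a third core: the limit of > 50000 nM in this assay, at which 1 of the 4 values shown sits.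

The swap changes the atom and the ring position together, leaving open how much each contributes, which 3-hydroxyphenyl or 4-aminophenyl on these cores would help to separate. Also open, as far as these compounds go, is how other groups in the same place, such as a carboxylic acid or an amide, would read in this assay, and whether the difference between the two cores would persist with them.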